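This account rests on a few compounds, and the source may have more. Where it says the series, first, only, none or still open, it means among the compounds named here.

Measured so far in a toxicity assay on HT-29 cells (Homo sapiens) for cytotoxicity; on this read-out lower numbers stand for higher toxicity in this test and higher numbers for lower toxicity in this test:
compound 1 `CN1C(=S)[C@@H](NC(=O)c2nc(Cc3ccccc3)n(CCCC(F)(F)F)n2)COc2ccccc21` gives > 100000 nM
compound 2 `CN1C(=S)[C@@H](NC(=O)c2nc(Cc3ccccc3)n(CCCC#N)n2)COc2ccccc21` gives > 100000 nM
compound 3 `CN1C(=S)[C@@H](NC(=O)c2nc(Cc3ccccc3)n(C3CCCC3)n2)COc2ccccc21` gives > 100000 nM

The value of compound 1 is a limit of this assay, not a number. The same holds for compound 2. Compound 3 also stands at a limit, namely (the limit of > 100000 nM in this assay, at which 3 of the 3 values shown sit). Accordingly the steps a step that the two limits leave unreadable from compound 1 to compound 2, a step that the two limits leave unreadable from compound 1 to compound 3 and a step that the two limits leave unreadable from compound 2 to compound 3 give no readable size. Compound 4 `CN1C(=S)[C@@H](NC(=O)c2nc(Cc3ccccc3)n(-c3ncccn3)n2)COc2ccccc21` is not yet measured; it differs from compound 3 by pyrimidin-2-yl in place of cyclopentyl on an aromatic nitrogen. No measured step bears on this exchange, and nothing shown so far rises above the limit in this assay. The expectation for compound 4 is therefore that this assay again reports a limit, with the step that the limit leaves unreadable from compound 3 to compound 4 estimated as none beyond the scatter. Compound 4 is estimated at 150000 nM, in the range 40000 nM to 500000 nM.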

Compound 4, half-maximal cytotoxic concentration: > 100000 nM
Compound 4 ended at the assay's limit; the forecaster's own chance of this, stated with the estimate: 85%; the middle value does not contradict the limit.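

No step from compound 1, compound 2 or compound 3 to compound 4 can be read, since all four compounds stand at a limit: the limit of > 100000 nM in this assay, at which 4 of the 4 values shown sit.

As far as these compounds go, whether the 4,4,4-trifluorobutyl, 3-cyanopropyl, cyclopentyl and pyrimidin-2-yl groups differ at all in this assay stays open.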